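A few compounds are considered here, and "the series" means these few. Any claim that something is new, unique, unknown or untested is made for them only; others in the source may bear on it.

Measured compounds:
- compound 1, `Cc1ccc(-c2nc(CNc3ccc(C(=O)NO)cc3)n(-c3ccccc3)n2)cc1` — 62.2%
- compound 2, `Cc1ccccc1-c1nc(CNc2ccc(C(=O)NO)cc2)n(-c2ccccc2)n1` — 53.2%
- compound 3, `O=C(O)c1ccc(NCc2nc(-c3ccccc3)nn2-c2ccccc2)cc1` — -0.4%

In an assay on Sf9 cells for inhibition of protein deacetylase HDAC6 (Homo sapiens), read by fluorescence, with a stated time of 40 min, tested at 100 nM (a higher number here means more inhibition at the concentration tested (going by the name of the read-out), a lower number less inhibition), compound 1 gives 62.2%, the highest of the three numbers shown. Compound 2 stands nearest, with a number 9 percentage points lower from compound 1 to compound 2 (within the scatter), so the two cannot be placed in any order. Going by the values given here, compound 3 lies furthest away with -0.4%, a gap well beyond the scatter; no single step connects it to compound 1, so only the two values themselves can be compared.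

Compound 4, `CC(C)c1ccc(-c2nc(CNc3ccc(C(=O)NO)cc3)n(-c3ccccc3)n2)cc1`, differs from compound 1 by isopropyl in place of methyl on an aromatic carbon. Among the compounds with values here, none of the measured steps changes the same group: the only step available, from 4-methylphenyl to 2-methylphenyl, moved the methyl rather than enlarging it, and stayed within the scatter. Since the two compounds that keep the hydroxamic acid sit close together, the isopropyl is expected to leave the inhibition roughly where compound 1 stands, with the step of a number 2.2 percentage points lower from compound 1 to compound 4 (within the scatter) expected to be small. Compound 4 is therefore estimated at 60%, within 40% to 78%.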

Compound 4, a percentage reported as inhibition, at one concentration (the size of the read-out at that concentration, not a potency): 27.6%
Beside the measured number, compound 4's estimate is 32.4 percentage points above it; the whole stated range lies above it.
By their numbers in this assay, from the lowest: compound 3; then compound 4; then compounds 2 and 1 (each within the scatter of the next).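

In this assay, going by these compounds alone, the position para to a large group proves not to accept every small carbon group alike: isopropyl in place of methyl gives a number 34.6 percentage points lower from compound 1 to compound 4 (beyond the scatter), the first change on this aryl ring to reach beyond the scatter. The earlier move of the methyl gave only a number 9 percentage points lower from compound 1 to compound 2 (within the scatter), whereas the step to the 4-isopropylphenyl compound gives a number 25.6 percentage points lower from compound 2 to compound 4 (beyond the scatter), so inhibition here depends on which group the ring carries and not merely on the presence of a hydroxamic acid. No supporting data are available to explain this loss.

The compounds shown leave open whether inhibition falls gradually or abruptly between methyl and isopropyl, since an ethyl group would be the intermediate case. They also leave open how groups containing other atoms, such as a methoxy group or a fluorine, would behave at this place.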